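The source may hold more compounds than are shown below. What is called first, only, known or untested is meant among the compounds shown, and "the series" means these compounds.

In a functional assay on FM3A cells (Mus musculus) for antiproliferative activity, with a stated time of 48 h (a lower number here means a stronger inhibitor, a higher number a weaker inhibitor), compound 1 `C=C(Br)C(=O)Nc1ccc(/C=C/C(=O)c2ccc(Br)cc2)cc1` gives 1100 nM and compound 2 `C=C(Br)C(=O)Nc1ccc(C(=O)/C=C/c2ccc(OC)cc2)cc1` gives 1000 nM while compound 3 `C=C(Br)C(=O)Nc1ccc(C(=O)/C=C/c2cccc(OC)c2)cc1` gives 1800 nM as the third value. The number for compound 3 lies within the scatter of both other values, so it stands clearly apart from neither. The unmeasured compound 4 `C=C(Br)C(=O)Nc1ccc(C(=O)/C=C/c2cccc(OC)c2OC)cc1` differs from compound 3 by a single change, methoxy in place of hydrogen on an aromatic carbon as a methoxy in place of hydrogen on an aromatic carbon, ortho to a large group and ortho to a methoxy group. Within the data shown here, no measured step adds a group of this kind. The closest evidence is a 1.8-fold higher number from compound 2 to compound 3 (0.26 log units; within the scatter) for 3-methoxyphenyl in place of 4-methoxyphenyl, and that step stays within the scatter. It concerns a shifted methoxy rather than an added one, so it bears on the new change only loosely. On these data alone, no shift beyond the scatter is therefore expected in this assay and the direction remains open. The estimated step is a 1.2-fold lower number from compound 3 to compound 4 (0.08 log units; within the scatter) and so is expected to remain small. For compound 4 the estimate in this assay is 1500 nM with 600 nM to 3500 nM as its expected range.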

Compound 4, half-maximal inhibitory concentration: 550 nM
Compound 4: middle estimate off by 2.7-fold (0.44 log units), on the high side; the measured number lies below the stated range.
By their numbers in this assay, from the lowest: compounds 4, 2, 1 and 3 (each within the scatter of the next, the first and the last beyond it).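

Putting a methoxy in place of hydrogen on an aromatic carbon, ortho to a large group and ortho to a methoxy group, gives a 3.3-fold lower number from compound 3 to compound 4 (0.51 log units; beyond the scatter) in this assay, the only step shown that passes beyond the scatter. Among these compounds, the earlier step, a 1.8-fold higher number from compound 2 to compound 3 (0.26 log units; within the scatter), shifted a methoxy rather than added one and stayed within the scatter, so this is the first sign that the substitution of this aromatic ring can move the number at all. Nothing available accounts for this gain.

The compounds shown leave open whether the gain belongs to the methoxy itself or would also appear with a hydroxyl, a fluorine or an ethoxy at this position. They also leave open whether a methoxy here would give a similar step without the neighbouring methoxy group already present in compound 3.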